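Sulfonyl for phenol hydrogen across two cores, all at limit

The source may report more compounds than this note shows. Statements on the series, on what has been measured and on what is new or still open speak of the compounds shown alone.

Compound 1 `C=C1C[C@]23C[C@@]1(O)CC[C@H]2c1ccc(O)c(C)c1[C@@H]3Cn1cc(-c2ccccc2)nn1` and compound 2 `Cc1ccc(-c2cn(C[C@H]3c4c(ccc(O)c4C)[C@@H]4CC[C@@]5(C)C[C@]43CC5=O)nn2)cc1` share much of their structure but differ in their cores; the difference between the two cores is not broken down here. In a functional assay on MCF7 cells (Homo sapiens) for cytotoxicity, read by MTT assay, with a stated time of 4 days (a lower number here means a stronger inhibitor, a higher number a weaker inhibitor), compound 1 gives only the limit > 20000 nM. Compound 2 gives the limit > 20000 nM in this assay. Compound 3 `Cc1ccc(-c2cn(C[C@H]3c4c(ccc(OS(=O)(=O)c5ccc(C)cc5)c4C)[C@@H]4CC[C@@]5(C)C[C@]43CC5=O)nn2)cc1` carries (4-methylphenyl)sulfonyl in place of hydrogen on an oxygen on an aromatic ring and gives the limit > 20000 nM in this assay. The step that the two limits leave unreadable from compound 2 to compound 3 cannot be sized because the limit of > 20000 nM in this assay, at which 3 of the 3 values shown sit, covers both ends of it.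

Compound 4 `C=C1C[C@]23C[C@@]1(O)CC[C@H]2c1ccc(OS(=O)(=O)c2ccc(C)cc2)c(C)c1[C@@H]3Cn1cc(-c2ccccc2)nn1` carries (4-methylphenyl)sulfonyl in place of hydrogen on an oxygen on an aromatic ring, the same change at the same place as in compound 3. Since compound 1 sits at > 20000 nM and the measured step that the two limits leave unreadable from compound 2 to compound 3 is unreadable, the expected step that the limit leaves unreadable from compound 1 to compound 4 is taken as flat. Compound 4 is therefore estimated at 30000 nM, between 8000 nM and 120000 nM, most likely reported as a limit again.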

Compound 4, half-maximal inhibitory concentration: > 20000 nM
Compound 4 gave a limit, no number; the forecaster's own chance of this, stated with the estimate: 80%; the middle value does not contradict the limit.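

The step from compound 1 to compound 4 cannot be read, because both compounds give only a limit: the limit of > 20000 nM in this assay, at which 4 of the 4 values shown sit.

On these data alone, whether (4-methylphenyl)sulfonyl in place of hydrogen alters activity on either core, and how the four compounds rank against one another, remains open.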